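The source may hold more compounds than are shown below. What is called first, only, known or untested is meant among the compounds shown, and "the series" means these compounds.

Working notes on the series. Compound 3 `C=C(Br)C(=O)Nc1cccc(-c2cn3nc(-c4ccc(Cl)cc4)sc3n2)c1` gives 3200 nM in a functional assay on CCRF-CEM cells (Homo sapiens) for inhibition, read by cell counting, with a stated time of 3 days; on this read-out lower numbers stand for stronger inhibition and higher numbers for weaker inhibition. Among the three measured compounds it stands second highest: the nearest is compound 1 `C=C(Br)C(=O)Nc1cccc(-c2cn3nc(-c4ccc(OCC)cc4)sc3n2)c1` at 1400 nM, and the furthest is compound 2 `Nc1cccc(-c2cn3nc(Cc4ccc(Cl)cc4)sc3n2)c1` at 42000 nM. For the measured compounds named here, the one measured step that reaches compound 3, a 2.3-fold higher number from compound 1 to compound 3 (0.36 log units; beyond the scatter), concerns the other end of the core and does not touch the change considered here.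

Compound 4 `C=C(Br)C(=O)Nc1cccc(-c2cn3nc(Cc4ccc(Cl)cc4)sc3n2)c1` is not yet measured. It differs from compound 3 by 4-chlorobenzyl in place of 4-chlorophenyl on an aromatic carbon. Going by the values given here, no measured pair isolates this exchange, so the direction is open. Among the compounds with values here, compound 4 shares the 4-chlorobenzyl with compound 2, which differs from it elsewhere, so the value of compound 2, 42000 nM, sets no step. Given the absence of a bearing step, compound 4 is expected to show only a modest change in this assay, estimated as a 1.6-fold higher number from compound 3 to compound 4 (0.19 log units; within the scatter), with a wide margin. The estimate for compound 4 is 5000 nM, expected between 1500 nM and 20000 nM.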

Compound 4, half-maximal inhibitory concentration: 3300 nM
The estimate for compound 4 lay 1.5-fold (0.18 log units) above the measured number, within the range that was stated.
By their numbers in this assay, from the lowest: compound 1; then compounds 3 and 4 (each within the scatter of the next); then compound 2.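

At this position, the first measured pair isolating the exchange does not separate 4-chlorobenzyl from 4-chlorophenyl in this assay (a 1.0-fold higher number from compound 3 to compound 4 (0.01 log units; within the scatter)). With 4-chlorobenzyl held constant, placing (1-bromoethenyl)carbonyl on the nitrogen in place of hydrogen gives a large step (a 13-fold lower number from compound 2 to compound 4 (1.10 log units; beyond the scatter)), whereas the comparison with 4-ethoxyphenyl at the core's other end gives only a modest one (a 2.4-fold higher number from compound 1 to compound 4 (0.37 log units; beyond the scatter)). No measurement shown offers an explanation for any of these steps.

Going by these compounds, it remains open whether a longer chain, such as 2-(4-chlorophenyl)ethyl, or an amine on this aromatic carbon would also leave the number unchanged. On these data alone, how an acetyl group on the nitrogen would compare with (1-bromoethenyl)carbonyl also stays open.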